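Removing a chloro group from a dichlorinated purine-like core

The source may hold more compounds than are shown below. What is called first, only, known or untested is meant among the compounds shown, and "the series" means these compounds.

Compound 1 `ClCc1ccc(Cn2cnc3c(Cl)ncnc32)cc1` — 5370 nM
Compound 2 `ClCc1cccc(Cn2cnc3ncnc(Cl)c32)c1` — 6160 nM
Compound 3 `ClCc1ccc(Cn2cnc3nc(Cl)nc(Cl)c32)cc1` — 6600 nM

Of the compounds shown here, three have been measured in a functional assay on SN12C cells (Homo sapiens) for cytotoxicity, read by sulforhodamine B assay, with a stated time of 48 h; a lower number here means that less compound is tolerated, a higher number that more compound is tolerated. Compound 1 `ClCc1ccc(Cn2cnc3c(Cl)ncnc32)cc1` gives 5370 nM, compound 2 `ClCc1cccc(Cn2cnc3ncnc(Cl)c32)c1` gives 6160 nM, and compound 3 `ClCc1ccc(Cn2cnc3nc(Cl)nc(Cl)c32)cc1` gives 6600 nM. Compound 3 carries the highest of the three numbers, yet its nearest neighbour, compound 2, lies only a little lower and even compound 1, the furthest away, sits within the scatter of repeated measurements, so the three values cannot be told apart.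

Compound 4 `ClCc1ccc(Cn2cnc3ncnc(Cl)c32)cc1` has not yet been measured in this assay. It differs from compound 3 in one place: hydrogen in place of chloro on an aromatic carbon. Compound 2 shares this single-chloro core and still gives a value indistinguishable from that of compound 3, so the second chloro group on the core does not show any effect in the measured set. The step from compound 3 to compound 4 is therefore expected to be none beyond the scatter. On this basis compound 4 is estimated to give 5900 nM, within a range of 3000 nM to 11500 nM, which means an expected step of a 1.1-fold lower number from compound 3 to compound 4 (0.05 log units; within the scatter).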

Compound 4, concentration lethal to 50% of the cells: 40700 nM
For compound 4 the middle estimate is 6.9-fold (0.84 log units) below the measured one; measured number above the stated range.
By their numbers in this assay, from the lowest: compounds 1, 2 and 3 (each within the scatter of the next); then compound 4.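

In this assay, hydrogen in place of chloro on the aromatic carbon between two ring nitrogen atoms gives a 6.2-fold higher number from compound 3 to compound 4 (0.79 log units; beyond the scatter), so this position does matter, a step that lies beyond the scatter and that the three earlier compounds, all within the scatter of one another, gave no sign of. The single-chloro core alone does not carry the step: compound 2 shares that core and differs from compound 4 only in where the chloromethyl group sits on the outer ring, yet compound 2 gives 6160 nM and compound 4 gives 40700 nM, so the outcome of losing this chloro group appears tied to the placement of the chloromethyl group. Nothing measured here accounts for the step.

The compounds shown leave open whether hydrogen is special at this position or whether an amine, a methoxy group or a fluoro group there would give a number like that of compound 3 or like that of compound 4. They also leave open whether the step holds with the chloromethyl group replaced by a plain methyl group.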